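A few compounds are considered here, and "the series" means these few. Any claim that something is new, unique, unknown or untested is made for them only; others in the source may bear on it.

Of the compounds shown here, three sharing one core have been tested in an assay on isolated protein for inhibition of retinal dehydrogenase 2 (Homo sapiens); on this read-out higher numbers stand for weaker inhibition and lower numbers for stronger inhibition. Compound 1 `CC(Sc1nc2c(cnn2C)c(=O)n1-c1ccccc1)c1ccccn1` gives 63 nM. Differing from compound 1 elsewhere on the core, compound 3 `CC(Sc1nc2nn(C3COC3)cc2c(=O)n1-c1ccccc1)c1ccccn1` gives 21 nM. Compound 2 `Cn1ncc2c(=O)n(-c3ccccc3)c(OCc3cccc(F)c3)nc21`, whose side chain is joined to the core through oxygen rather than sulfur, gives 3700 nM. Among these three numbers compound 1 stands second highest: compound 3 lies lower, beyond the usual scatter, and compound 2 lies far higher, also beyond the scatter. No two of the measured compounds differ from each other in only one place, so no single exchange has yet been tied to a change in the read-out.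

Compound 4 `COc1ccccc1C(C)Sc1nc2c(cnn2C)c(=O)n1-c1ccccc1` differs from compound 1 in one place: 2-methoxyphenyl in place of pyridin-2-yl on a saturated chain carbon bound to a saturated chain carbon and a sulfur. Within the data shown here, none of the measured compounds shows the outcome of such an exchange, so the expectation rests on compound 1 alone. Because compound 1 gives 63 nM and the exchange keeps one hydrogen-bond acceptor while removing the ring nitrogen, the step from compound 1 to compound 4 is expected to be modest, toward weaker inhibition, a 2.4-fold higher number from compound 1 to compound 4 (0.38 log units; beyond the scatter). Compound 4 is therefore estimated at 150 nM, with a range from 40 nM to 600 nM.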

Compound 4, half-maximal inhibitory concentration: 136 nM
Estimate against measurement, compound 4: 1.1-fold (0.04 log units) above; the range from low to high includes it.
By their numbers in this assay, from the lowest: compound 3; then compound 1; then compound 4; then compound 2.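

In this assay, compound 1 and compound 4 are the first pair shown that differ in only one place, on a saturated chain carbon bound to a saturated chain carbon and a sulfur, and this gives a first direct reading of a change there. Replacing pyridin-2-yl with 2-methoxyphenyl gives a 2.2-fold higher number from compound 1 to compound 4 (0.33 log units; beyond the scatter): the step is real but modest, which shows that at least on this core, inhibition survives with a carbon-only aromatic ring at this position and does not depend on the pyridine ring nitrogen. No measurement available here accounts for the direction or size of this step.

The exchange removes a ring nitrogen and adds a methoxy group in a single move, and the compounds shown cannot separate the contribution of each, which a plain phenyl ring or a 2-methylphenyl group at the same place could help to do. On these data alone, it also remains open how this position would respond to a larger group such as a naphthyl ring, or to a charged one such as a carboxylic acid or an amine.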